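The source may report more compounds than this note shows. Statements on the series, on what has been measured and on what is new or still open speak of the compounds shown alone.

Measured compounds:
compound 1 `COc1cccc(CNC(=O)c2nc(Br)c3cccnc3c2N[C@H]2CC[C@H](N)CC2)c1` — 6000 nM
compound 2 `N[C@H]1CC[C@H](Nc2c(C(=O)NCc3ccccn3)nc(Br)c3cccnc23)CC1` — "not determined" (no result reported)
compound 3 `COC(=O)c1nc(Br)c2cccnc2c1N[C@H]1CC[C@H](N)CC1` — "not determined" (no result reported)

All four compounds share one core, which in compound 3 carries a methyl ester. For the measured compounds named here, in a functional assay on HCT-116 cells (Homo sapiens) for cytotoxicity, read by MTT assay, with a stated time of 72 h (on this read-out higher numbers stand for weaker inhibition and lower numbers for stronger inhibition), compound 1 gives 6000 nM, and this is the only number the set offers. Compound 2 and compound 3 were both run without a reported result, so compound 3 stands on no number at all, and nothing in the data tells how it compares with compound 1.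

The step under consideration leads from compound 3 to compound 4 `N[C@H]1CC[C@H](Nc2c(C(=O)NCc3ccc(Cl)cc3Cl)nc(Br)c3cccnc23)CC1` and involves ((2,4-dichlorobenzyl)amino in place of methoxy on a carbonyl carbon). Compound 1 is the nearest guide, since it also has an amide with a substituted benzyl group on the carbonyl carbon. Going by the values given here, because compound 3 has no value, no size or direction of step in this assay can be stated for this change; what can be said is that compound 4 is expected to land near the only reported number, that of compound 1, because 6000 nM is the sole anchor.

Compound 4 is therefore estimated at 4000 nM, with a plausible range from 1000 nM to 15000 nM.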

Compound 4, half-maximal inhibitory concentration: 6000 nM
Compound 4: middle estimate off by 1.5-fold (0.18 log units), on the low side; measured number inside the range.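

In this assay, for the compounds shown here, placing 2,4-dichlorophenyl in place of 3-methoxyphenyl on a saturated chain carbon bound to an amide-type nitrogen gives no change at the digits printed from compound 1 to compound 4 (within the scatter), so this pair offers the first comparison at this position, and the two substituted benzyl amides cannot be told apart on this read-out. Compound 3 has no number, so the exchange of its methoxy for (2,4-dichlorobenzyl)amino on the carbonyl carbon cannot be read as a step, and the effect of going from the methyl ester to an amide remains unmeasured in this set. Nothing measured here offers an explanation for the result.

The compounds shown leave open how the assay would read a carboxylic acid or an unsubstituted primary amide on the same carbonyl carbon, either of which would remove the benzyl group altogether. They also leave open whether a longer chain between the amide nitrogen and the ring, or a trifluoromethyl group on that ring, would separate from compound 1 and compound 4.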